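The compounds below may be only part of what the source reports. "The series", "measured", "known", "first", "only" and "open" are said of these compounds alone.

Measured compounds:
compound 1, `CN(C)Cc1ccc(-c2cnc(N)c(C(=O)NC3CCC(O)CC3)n2)cc1`: 850000 nM
compound 2, `Nc1ncc(-c2ccc(CN3CCC(N4CCCC4)CC3)cc2)nc1C(=O)N[C@H]1CC[C@H](O)CC1`: > 1000000 nM; > 1000000 nM (2 entries)

In a physicochemical assay for solubility, at pH 6.8 (a higher number here means a more soluble compound, a lower number a less soluble compound), compound 1 gives 850000 nM. For compound 2 this assay reports only a limit, > 1000000 nM; > 1000000 nM (2 entries), measured twice. For the measured compounds named here, compound 1 therefore carries the only definite number in the set, and it is a high one.

Compound 3, `CN(C)Cc1ccc(-c2cnc(N)c(C(=O)NC3CCCCC3)n2)cc1`, differs from compound 1 in one place: hydrogen in place of hydroxy on a saturated ring carbon. The hydroxy group on the saturated six-membered carbon ring leaves and a hydrogen enters, so compound 3 keeps the shared core and the dimethylaminomethyl-bearing aromatic ring unchanged.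

Going by the values given here, no measured pair in the set isolates this change, so the step cannot be read from data. The step from compound 1 to compound 3 is expected to lower solubility beyond the usual scatter, a 2.8-fold lower number from compound 1 to compound 3 (0.45 log units; beyond the scatter). Compound 3 is estimated at 300000 nM, with a range from 80000 nM to 900000 nM.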

Compound 3, solubility: 190000 nM
The estimate for compound 3 lay 1.6-fold (0.20 log units) above the measured number; the range from low to high includes it.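

For the compounds shown here, until now, no measured pair isolated the hydroxy group on the saturated six-membered carbon ring. In this assay, the change from 4-hydroxycyclohexyl to cyclohexyl gives a 4.5-fold lower number from compound 1 to compound 3 (0.65 log units; beyond the scatter) and so has a measured size at this position, with the shared core and the dimethylaminomethyl-bearing aromatic ring left unchanged. No measurement shown here accounts for the size of this step.

The compounds shown give only hydroxy and hydrogen at this ring carbon, so they leave open how a methoxy group, an amine or a carboxylic acid in the same place would read in this assay. They also leave open whether the same exchange would give a step of similar size in a compound with the larger amine-bearing side chain of compound 2.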